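The compounds below may be only part of what the source reports. "The series", "measured", "known", "first", "only" and "open" are said of these compounds alone.

Measured compounds in an ADME assay on cells (Mus musculus, strain BALB/c) for cytotoxicity, read by MTT assay, with a stated time of 24 h; on this read-out lower numbers stand for higher toxicity in this test and higher numbers for lower toxicity in this test:
compound 1, `COc1cc(-c2nnc(SCc3ccc(C)cc3)o2)ccc1O`: 549000 nM
compound 2, `COc1cc(-c2nnc(SCc3cccc([N+](=O)[O-])c3)o2)ccc1O`: 392000 nM
compound 3, `COc1cc(-c2nnc(SCc3ccc(Cl)cc3)o2)ccc1O`: 480000 nM

The three compounds share one core and differ only in the aryl group on the saturated chain carbon bound to a sulfur. Compound 1 gives the highest of the three numbers in this assay, but its nearest neighbour, compound 3, and its furthest, compound 2, both sit within the scatter of it, so the three values cannot be ordered with any confidence.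

Compound 4, `COc1cccc(CSc2nnc(-c3ccc(O)c(OC)c3)o2)c1`, is the next member of the series and has not been measured. Against compound 1 the change is 3-methoxyphenyl in place of 4-methylphenyl on a saturated chain carbon bound to a sulfur. For the measured compounds named here, the one measured step at this position is a 1.1-fold lower number from compound 1 to compound 3 (0.06 log units; within the scatter), a change of the same kind at the same place that did nothing beyond the scatter. Compound 2 carries a different group at this position and gives 392000 nM, again close to compound 1. Going by the values given here, nothing so far suggests that a change of the aryl substituent moves this read-out, so the step of a 1.2-fold lower number from compound 1 to compound 4 (0.07 log units; within the scatter) is expected to stay within the scatter. Compound 4 is therefore estimated at 470000 nM, with a range from 260000 nM to 800000 nM.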

Compound 4, half-maximal cytotoxic concentration: 389000 nM
For compound 4 the middle estimate is 1.2-fold (0.08 log units) above the measured one; the range from low to high includes it.
By their numbers in this assay, from the lowest: compounds 4, 2, 3 and 1 (each within the scatter of the next).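

Across the aryl groups on the saturated chain carbon bound to a sulfur, this assay still does not separate the compounds: 3-methoxyphenyl in place of 4-methylphenyl gives a 1.4-fold lower number from compound 1 to compound 4 (0.15 log units; within the scatter), and 3-methoxyphenyl in place of 4-chlorophenyl gives a 1.2-fold lower number from compound 3 to compound 4 (0.09 log units; within the scatter). For the compounds shown here, these steps add a group counted with a hydrogen-bond acceptor where the leaving aryl groups of compound 1 and compound 3 differ from it in kind, yet both stay within the scatter, so the flat picture now extends beyond the single earlier step. Methoxy in place of nitro on an aromatic carbon gives a 1.0-fold lower number from compound 2 to compound 4 (0.00 log units; within the scatter), so this exchange also leaves the read-out within the scatter, and the data shown offer no explanation for the flat response.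

From the compounds shown here alone, all four compounds keep a substituted phenyl group at this place, so it remains open whether an aminomethyl group or a carboxylic acid on that ring, or a longer chain between the sulfur and the ring, would move the read-out beyond the scatter. The compounds shown also leave open what a change to the shared core itself would do in this assay, since every variation so far lies on the aryl group.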